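Swapping Dichlorophenyl for Dimethoxyphenyl on a Shared Core

The source may hold more compounds than are shown below. What is called first, only, known or untested is meant among the compounds shown, and "the series" means these compounds.

Measured so far in a functional assay on COLO 205 cells (Homo sapiens) for inhibition, read by sulforhodamine B assay, with a stated time of 48 h; on this read-out lower numbers stand for stronger inhibition of growth and higher numbers for weaker inhibition of growth:
Compound 1 `Nc1cc(N)c2nc(-c3ccccc3)c(Oc3ccc(Cl)c(Cl)c3)nc2c1` gives 67600 nM.
Compound 2 `CCOC(=O)[C@H](CCC(=O)O)NC(=O)c1ccc(CNc2nc3cc(N)cc(N)c3nc2-c2ccccc2)cc1` gives < 100000 nM, which is a limit of the assay and not a number.
Compound 3 `Nc1cc(N)c2nc(-c3ccccc3)c(NCc3ccc(Cl)c(Cl)c3)nc2c1` gives 33900 nM.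

Compound 3 holds the lower of the two numbers, but the gap to compound 1 lies within the usual scatter, so no order can be read between them. Compound 4 `COc1ccc(CNc2nc3cc(N)cc(N)c3nc2-c2ccccc2)cc1OC` is not yet measured; it differs from compound 3 by 3,4-dimethoxyphenyl in place of 3,4-dichlorophenyl on a saturated chain carbon bound to a nitrogen on an aromatic ring. Among the compounds with values here, no two measured compounds differ in only one place, so no measured step guides the expectation. The expected step in this assay is a 1.3-fold higher number from compound 3 to compound 4 (0.12 log units; within the scatter), no larger than the scatter in either direction. Compound 4 is therefore expected to give about 45000 nM, within 15000 nM to 100000 nM.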

Compound 4, concentration for total growth inhibition: < 100000 nM
Compound 4: no number, only a limit; the forecaster's own chance of this, stated with the estimate: 25%; the middle value lies beyond the limit too.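

Within the data shown here, the result for compound 4 is a limit of the assay and not a number, so no step from compound 3 to compound 4 can be read: the limit of < 100000 nM in this assay, at which 2 of the 4 values shown sit. Going by these compounds, whether 3,4-dimethoxyphenyl in place of 3,4-dichlorophenyl alters growth inhibition on the shared core stays open.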